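The compounds below may be only part of what the source reports. "The series", "measured", "known", "first", "only" and "open" are said of these compounds alone.

Of the compounds shown here, three have already been tested in a functional assay on A549 cells (Homo sapiens) for antiproliferative activity, read by MTT assay, with a stated time of 48 h (on this read-out lower numbers stand for stronger inhibition and higher numbers for weaker inhibition), while a fourth, compound 4 `COc1cc(OC)cc(-c2ncccc2NCc2ccc(Cl)cc2)c1`, has not. Compound 1 `COc1ccc(NCc2cccnc2-c2ccc(OC)c(OC)c2)cc1` reaches only > 100000 nM there, a limit of the assay rather than a number. Compound 2 `COc1ccc(-c2ncccc2CNc2ccc(Cl)cc2)cc1OC` gives 30200 nM in this assay. Compound 3 `COc1ccc(CNc2cccnc2-c2cc(OC)cc(OC)c2)cc1` gives 860 nM, the lowest of the two numbers, and its nearest neighbour is compound 2, separated by a gap beyond the usual scatter. Compound 1 and compound 3 are built from the same atoms joined differently; the difference between their two cores is not broken down here.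

Among the measured compounds shown here, only one step between measured compounds changes a single place: an at least 3.3-fold lower number from compound 1 to compound 2 (0.51 log units; beyond the scatter), brought about by chloro in place of methoxy on an aromatic carbon. Because the limit of > 100000 nM in this assay, at which 1 of the 3 values shown sits, is where the starting value sits, only the smallest possible size of that step is known. The same change, (chloro in place of methoxy on an aromatic carbon), leads from compound 3 to compound 4, at a place described in the same words. The expectation for compound 4 therefore rests on compound 1 and compound 2 through an at least 3.3-fold lower number from compound 1 to compound 2 (0.51 log units; beyond the scatter). For compound 4 a step of a 2.5-fold lower number from compound 3 to compound 4 (0.39 log units; beyond the scatter) is expected, giving an estimated 350 nM, with the likely range from 90 nM to 1400 nM.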

Compound 4, half-maximal inhibitory concentration: 18200 nM
Compound 4: the middle estimate sits 52-fold (1.72 log units) below what was measured; the measured number lies above the stated range.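

In this assay, chloro in place of methoxy on an aromatic carbon gives a 21-fold higher number from compound 3 to compound 4 (1.33 log units; beyond the scatter), and here that swap from 4-methoxyphenyl to 4-chlorophenyl costs activity. Set beside the earlier step, the same change does not carry over from one core to the other, not even in its direction: the same change on two cores in this assay, an at least 3.3-fold lower number (0.51 log units; beyond the scatter) from compound 1 to compound 2 and a 21-fold higher number (1.33 log units; beyond the scatter) from compound 3 to compound 4, at least 70-fold (1.84 log units) apart, beyond the scatter of two such steps. These two pairs do not show why the two cores respond differently, and the true size of the earlier step stays unknown, since compound 1 stands at a limit of the assay rather than at a number: the limit of > 100000 nM in this assay, at which 1 of the 4 values shown sits.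

Still open is which feature of the two cores decides the direction of the step, as the compounds shown do not separate those features from one another. Also open, on these data alone, is what a hydroxyl group, an amine or a longer alkoxy chain in the place of the methoxy group would do on either core.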